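The source may hold more compounds than are shown below. What is called first, only, known or untested is meant among the compounds shown, and "the series" means these compounds.

Of the compounds shown here, three have so far been measured in an assay on isolated protein with Bile acid receptor (Homo sapiens) as the target; on this read-out higher numbers stand for an effect only at larger amounts of compound and lower numbers for an effect already at smaller amounts. Compound 1 `COC(=O)/C=C/c1cccc(N(Cc2ccc(-c3ccc(F)c(Cl)c3)cc2)C(=O)C2CCCCC2)c1` gives 66 nM in this assay. Compound 2 `COC(=O)/C=C/c1cccc(N(Cc2ccc(-c3ccc(N(C)C)cc3)cc2)C(=O)C(C)C)c1` gives 57 nM, a number within the scatter of that of compound 1, so the two cannot be ordered. Compound 3 `COC(=O)/C=C/c1cccc(N(Cc2ccc3c(c2OC)OC(C)(C)C=C3)C(=O)C2CCCCC2)c1` gives 358 nM, which lies beyond the scatter above compound 1; compound 1 therefore stands second highest of the three. Compound 4 `COC(=O)/C=C/c1cccc(N(Cc2ccc(/C=C/C(=O)OCc3ccccc3)cc2)C(=O)C2CCCCC2)c1` has not been measured. It differs from compound 1 in one place: 2-(benzyloxycarbonyl)ethenyl in place of 3-chloro-4-fluorophenyl on an aromatic carbon. Among the measured compounds shown here, no step between two measured compounds matches this change, so its size is uncertain; the author expects a modest move toward higher numbers in this assay, near the edge of the scatter, a 2.3-fold higher number from compound 1 to compound 4 (0.36 log units; beyond the scatter). For compound 4 the estimate is 150 nM, with a range from 50 nM to 500 nM.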

Compound 4, half-maximal effective concentration: > 1000 nM
Compound 4 was reported as a limit; the forecaster's own chance of this, stated with the estimate: 5%; middle value at least 6.6-fold (0.82 log units) away from the limit.
By their numbers in this assay, from the lowest: compounds 2 and 1 (each within the scatter of the next); then compound 3. At a limit, above all of these: compound 4.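

In this assay compound 4 gives > 1000 nM, which is a limit and not a number. The change to 2-(benzyloxycarbonyl)ethenyl in place of 3-chloro-4-fluorophenyl gives an at least 15-fold higher number from compound 1 to compound 4 (1.18 log units; beyond the scatter), the first sign that this position is sensitive to what it carries. Both groups hold a six-membered aromatic ring of carbon, so that ring alone does not keep the number of compound 1.

The compounds shown leave open whether the ethenyl link, the ester or the benzyl part accounts for the step. A carboxylic acid or a methyl ester on the same ethenyl chain would separate these.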